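Swapping methoxy for carboxy near an assay limit

The compounds below may be only part of what the source reports. "The series", "measured", "known", "first", "only" and "open" are said of these compounds alone.

Within the data shown here, in a functional assay on HEL cells (Homo sapiens) (on this read-out higher numbers stand for lower toxicity in this test and lower numbers for higher toxicity in this test), compound 2 `COC(=O)CNC1=CS(=O)(=O)O[C@@]12[C@@H](CO[Si](C)(C)C(C)(C)C)O[C@@H](n1cc(C)c(=O)n(C)c1=O)[C@@H]2O[Si](C)(C)C(C)(C)C` gives 160000 nM, the only true number among the three compounds measured so far. Compound 1 `CC(=O)NC1=CS(=O)(=O)O[C@@]12[C@@H](CO[Si](C)(C)C(C)(C)C)O[C@@H](n1cc(C)c(=O)n(C)c1=O)[C@@H]2O[Si](C)(C)C(C)(C)C` gives > 200000 nM, which is a limit of the assay and not a number. Compound 3 `Cc1cn([C@@H]2O[C@H](CO[Si](C)(C)C(C)(C)C)[C@@]3(OS(=O)(=O)C=C3NCC(=O)OCc3ccccc3)[C@H]2O[Si](C)(C)C(C)(C)C)c(=O)n(C)c1=O` gives > 200000 nM, which is also a limit. The data are therefore bounded by the limit of > 200000 nM in this assay, at which 2 of the 3 values shown sit.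

The unmeasured compound 4 `Cc1cn([C@@H]2O[C@H](CO[Si](C)(C)C(C)(C)C)[C@@]3(OS(=O)(=O)C=C3NCC(=O)C(=O)O)[C@H]2O[Si](C)(C)C(C)(C)C)c(=O)n(C)c1=O` keeps the shared core of compound 2 and differs in one group: carboxy in place of methoxy on a carbonyl carbon. Carboxy stands in place of methoxy on a carbonyl carbon, so (methoxycarbonyl)methyl becomes (carboxycarbonyl)methyl.

The closest guide is an at least 1.2-fold higher number from compound 2 to compound 3 (0.09 log units; that floor lies within the scatter), which also alters the methoxy end of compound 2. A broader guide is an at least 1.2-fold lower number from compound 1 to compound 2 (0.09 log units; that floor lies within the scatter), which swaps the whole group on the amine nitrogen. The remaining comparison is a step that the two limits leave unreadable from compound 1 to compound 3. Neither readable step establishes a change beyond the scatter, although each gives only a floor, so no step beyond the scatter is expected in this assay. The expected change is a 1.1-fold higher number from compound 2 to compound 4 (0.03 log units; within the scatter). Compound 4 is estimated at 170000 nM, with an expected range of 80000 nM to 350000 nM.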

Compound 4, half-maximal cytotoxic concentration: 146000 nM
Compound 4: the middle estimate sits 1.2-fold (0.07 log units) above what was measured; the measured number falls inside the stated range.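

In this assay, among these compounds, this position now has a true number at both ends of a change for the first time, and the result is a 1.1-fold lower number from compound 2 to compound 4 (0.04 log units; within the scatter) for carboxy in place of methoxy on a carbonyl carbon. The earlier readable steps gave only floors, whereas this one has a size, and it shows no change beyond the scatter even with carboxy bringing 1 hydrogen-bond donor where methoxy has 0. The other two new steps, an at least 1.3-fold lower number from compound 3 to compound 4 (0.13 log units; that floor lies within the scatter) and an at least 1.3-fold lower number from compound 1 to compound 4 (0.13 log units; that floor lies within the scatter), remain floors and give no full size because of what bounds these data: the limit of > 200000 nM in this assay, at which 2 of the 4 values shown sit.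

As far as these compounds go, whether an amine or a primary amide in place of methoxy on a carbonyl carbon would give a step beyond the scatter stays open. So does the effect of a longer chain between the amine nitrogen and the carboxy, since the compounds shown sample only methoxy, benzyloxy and carboxy at this end, plus the acetyl group on the nitrogen.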